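A few compounds are considered here, and "the series" means these few. Any claim that something is new, unique, unknown or untested is made for them only; others in the source may bear on it.

Measured so far in a functional assay on SH-SY5Y cells (Homo sapiens) for cytotoxicity, read by MTT assay, with stated times of 24 h and 4 h; on this read-out higher numbers stand for an effect only at larger amounts of compound and lower numbers for an effect already at smaller amounts:
- compound 1 `COc1cc(CNC(=O)/C=C/c2ccc(OCc3nc(C)c(C)nc3C)c(OC)c2)ccc1O` — compound 1 gives 10200 nM
- compound 2 `COc1cc(/C=C/C(=O)NCc2ccc(OCc3nc(C)c(C)nc3C)c(OC)c2)ccc1OCc1nc(C)c(C)nc1C` — compound 2 gives 11100 nM
- compound 3 `COc1cc(CNC(=O)/C=C/c2cc(OC)c(OC)c(OC)c2)ccc1O` — compound 3 gives 5910 nM

Compound 1 and compound 2 differ in one place: (3,5,6-trimethylpyrazin-2-yl)methyl in place of hydrogen on an oxygen on an aromatic ring. In this assay the change made a 1.1-fold higher number from compound 1 to compound 2 (0.04 log units; within the scatter), so the two values sit within the usual scatter of each other, and no direction can be read from this pair on its own. Compound 3 carries a different core; the difference between the core of compound 1 and the core of compound 3 is not broken down here, and the values of compound 1 and compound 3 lie within the scatter of each other.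

Compound 4 `COc1cc(CNC(=O)/C=C/c2cc(OC)c(OC)c(OC)c2)ccc1OCc1nc(C)c(C)nc1C` is not yet measured. It stands to compound 3 as compound 2 stands to compound 1: (3,5,6-trimethylpyrazin-2-yl)methyl in place of hydrogen on an oxygen on an aromatic ring. The place is described in the same words for both pairs, so this is the same change. The expectation for compound 4 rests on the single earlier case of this change, which gave a 1.1-fold higher number from compound 1 to compound 2 (0.04 log units; within the scatter); on that basis the step from compound 3 to compound 4 is estimated to be small, about a 1.1-fold higher number from compound 3 to compound 4 (0.04 log units; within the scatter). Compound 4 is thus expected to give about 6500 nM in this assay, with a likely range from 3500 nM to 12000 nM.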

Compound 4, half-maximal effective concentration: 11500 nM
Compound 4: the middle estimate sits 1.8-fold (0.25 log units) below what was measured; low and high end bracket the measured number.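

In this assay, (3,5,6-trimethylpyrazin-2-yl)methyl in place of hydrogen on an oxygen on an aromatic ring gives a 1.9-fold higher number from compound 3 to compound 4 (0.29 log units; within the scatter), a step that does not stand out from the usual scatter. Set beside the earlier case of the same change, this step does not differ from it: the same change on two cores in this assay, a 1.1-fold higher number (0.04 log units; within the scatter) from compound 1 to compound 2 and a 1.9-fold higher number (0.29 log units; within the scatter) from compound 3 to compound 4, 1.8-fold (0.25 log units) apart, within the scatter of two such steps

On these two cores, the change therefore carries over with no difference that can be resolved, but neither step is separated from the scatter, so this does not show that the change has a real effect, that it has none, or that the agreement would hold on a further core.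

On these data alone, it remains open whether an amine, a carboxylic acid or a longer alkyl chain on the same oxygen would move the number in this assay beyond the scatter. Also open, as far as these compounds go, is whether a plain methyl group there would read the same as (3,5,6-trimethylpyrazin-2-yl)methyl, which would show whether the pyrazine ring matters at all.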